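The compounds below may be only part of what the source reports. "The series", "measured", "known", "first", "only" and "open" are said of these compounds alone.

Compounds measured so far:

Compound 1, `Cc1cc(S(=O)(=O)/N=C(\N)n2nccc2-c2ccccc2)c(SCc2ccc(Cl)cc2)cc1Cl`, gives 7000 nM in a functional assay on HCT-116 cells (Homo sapiens) for cytotoxicity, read by MTT assay, with a stated time of 72 h; a higher number here means a weaker inhibitor, a lower number a stronger inhibitor.
Compound 2, `Cc1cc(-c2ccccc2)n(/C(N)=N/S(=O)(=O)c2cc(C)c(Cl)cc2SCc2ccccc2C(F)(F)F)n1`, gives 25000 nM in this assay.
Compound 3, `Cc1cc(S(=O)(=O)/N=C(\N)n2nccc2-c2ccccc2)c(SCc2ccccc2)cc1Cl`, gives 12000 nM in this assay.

Compound 2 stands at the highest number of the three, that is, as the weakest inhibitor among them; its nearest neighbour is compound 3, and compound 1 lies furthest from it, both gaps being beyond the usual scatter. Among the compounds with values here, the one step between compounds differing in a single place is a 1.7-fold higher number from compound 1 to compound 3 (0.23 log units; within the scatter), which concerns the benzyl ring but not the trifluoromethyl group.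

Compound 4, `Cc1cc(-c2ccccc2)n(/C(N)=N/S(=O)(=O)c2cc(C)c(Cl)cc2SCc2cccc(C(F)(F)F)c2)n1`, has not been measured. It differs from compound 2 in one place: 3-(trifluoromethyl)phenyl in place of 2-(trifluoromethyl)phenyl on a saturated chain carbon bound to a sulfur. Within the data shown here, no measured step bears directly on moving a trifluoromethyl group around this ring. Compounds 1 and 3 only show that varying the substitution on this benzyl ring changes the number modestly, and the comparison of compound 2 with compound 3 shows that adding the 2-(trifluoromethyl) group gave a higher number. The expected step of a 1.7-fold lower number from compound 2 to compound 4 (0.22 log units; within the scatter) is therefore a small move toward a lower number, with wide uncertainty. Compound 4 is expected to give about 15000 nM, within a range from 5000 nM to 45000 nM.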

Compound 4, half-maximal inhibitory concentration: 19000 nM
Compound 4: the middle estimate sits 1.3-fold (0.10 log units) below what was measured; low and high end bracket the measured number.
By their numbers in this assay, from the lowest: compounds 1, 3, 4 and 2 (each within the scatter of the next, the first and the last beyond it).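

Shifting the trifluoromethyl group, so that 3-(trifluoromethyl)phenyl replaces 2-(trifluoromethyl)phenyl on a saturated chain carbon bound to a sulfur, gives a 1.3-fold lower number from compound 2 to compound 4 (0.12 log units; within the scatter) in this assay. Within the data shown here, this is the first direct reading of where this group sits on the ring, and for this one pair the two placements cannot be told apart, since the step is no larger than repeated measurements of the same compound would be expected to differ. The atoms are the same on both sides, and the counts of heavy atoms, hydrogen-bond donors and acceptors do not change, but nothing available gives a reason for the result, and no separate measurement bears on it.

On these data alone, one pair cannot show whether this tolerance holds for other groups on the ring, so it remains open how a methoxy group, an amine or a carboxylic acid in place of the trifluoromethyl group would read in this assay. Also open, as far as these compounds go, is whether a longer chain in place of the benzyl group would leave the number where it is or shift it beyond the scatter.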